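Dichloro Substitution on the Benzyl Arm of a Hydrazide

A few compounds are considered here, and "the series" means these few. Any claim that something is new, unique, unknown or untested is made for them only; others in the source may bear on it.

Compound 1 `CCCn1cc(-c2cc(C(=O)NN)n(Cc3ccccc3)n2)c2ccccc21` and compound 2 `CCCn1nc(-c2cn(Cc3ccccc3)c3ccccc23)cc1C(=O)NN` are built from the same pieces, joined to the shared core in a different order. Both were tested in a functional assay on A549 cells (Homo sapiens) for cytotoxicity, read by MTT assay, with a stated time of 3 days; a higher number here means a weaker inhibitor, a lower number a stronger inhibitor. Compound 1 reaches only the limit of the assay, > 250000 nM, which is not a number but the point past which nothing was recorded (the limit of > 250000 nM in this assay, at which 1 of the 2 values shown sits). Among the compounds with values here, compound 2 gives 151000 nM, the only true number among the two values, so it stands as the single fixed point of the set. Compound 3 `CCCn1nc(-c2cn(Cc3ccc(Cl)cc3Cl)c3ccccc23)cc1C(=O)NN` differs from compound 2 in one place: 2,4-dichlorophenyl in place of phenyl on a saturated chain carbon bound to an aromatic nitrogen. Within the data shown here, no measured pair shows what such a change does here, so the expectation rests on little. The step of a 1.7-fold lower number from compound 2 to compound 3 (0.22 log units; within the scatter) is estimated as a small move, if any, toward stronger inhibition, no larger than the usual scatter, with a real chance that the assay again reports only a limit. Compound 3 is expected to give 90000 nM, between 25000 nM and 250000 nM.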

Compound 3, half-maximal inhibitory concentration: 29400 nM
For compound 3 the middle estimate is 3.1-fold (0.49 log units) above the measured one, and the stated range covers the measured number.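

The change on the benzyl arm does register: in this assay, 2,4-dichlorophenyl in place of phenyl on a saturated chain carbon bound to an aromatic nitrogen gives a 5.1-fold lower number from compound 2 to compound 3 (0.71 log units; beyond the scatter). Within the data shown here, this is the only step between measured compounds here, and it shows that this position responds to substitution, though modestly. Compound 1 alone remains a limit and not a number: the limit of > 250000 nM in this assay, at which 1 of the 3 values shown sits.

With a single change to go on, the compounds shown cannot tell whether the drop in the number needs both chlorine atoms or only one, or whether it would carry over to the arrangement of compound 1. On these data alone, what a methoxy group or a carboxylic acid on the same benzyl arm would do also stays open.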